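Swapping a cyclohexylmethyl amide for a 4-ethylphenyl one

A few compounds are considered here, and "the series" means these few. Any claim that something is new, unique, unknown or untested is made for them only; others in the source may bear on it.

Three members of this series have been tested in an ADME assay on HCT-116 cells (Homo sapiens) for cytotoxicity, read by MTT assay, with a stated time of 72 h; on this read-out higher numbers stand for weaker inhibition and lower numbers for stronger inhibition. Compound 1, with structure `O=C(NCC1CCCCC1)c1cccc(/C=C2\CC(=O)N(c3ccccc3)C2=O)c1`, carries a cyclohexylmethyl group on its amide nitrogen. In this assay compound 1 reaches only the limit of > 100000 nM, which is a boundary of the measurement rather than a number. Compound 2, with structure `CCc1cccc(NC(=O)c2cccc(/C=C3\CC(=O)N(Cc4ccccc4)C3=O)c2)c1`, gives 80600 nM in this assay. Compound 3, with structure `Cc1ccc(N2C(=O)C/C(=C\c3cccc(C(=O)Nc4ccc(Cl)cc4)c3)C2=O)cc1`, again returns only the limit of > 100000 nM in this assay. Across the three, the picture is of very weak cytotoxicity, and the limit of > 100000 nM in this assay, at which 2 of the 3 values shown sit, is where most of the values sit.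

The compound waiting to be measured is compound 4, with structure `CCc1ccc(NC(=O)c2cccc(/C=C3\CC(=O)N(c4ccccc4)C3=O)c2)cc1`. It differs from compound 1 in a single place: 4-ethylphenyl in place of cyclohexylmethyl on an amide-type nitrogen. The shared core is untouched.

Among the measured compounds shown here, no measured pair differs in just one place, so no direct precedent for this swap exists. Given that compound 1 sits at the limit and compound 2 shows that a related aryl amide is also very weak, the expectation is no shift beyond the scatter, expressed as an at least 1.0-fold lower number from compound 1 to compound 4 (0.02 log units; that floor lies within the scatter). Compound 4 is estimated at 95000 nM, in a range from 40000 nM to 300000 nM.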

Compound 4, half-maximal inhibitory concentration: > 100000 nM
Compound 4 was reported as a limit; the forecaster's own chance of this, stated with the estimate: 55%; middle value at least 1.0-fold (0.02 log units) away from the limit.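

Among the compounds shown here, compound 1 and compound 4 both stand only at a limit in this assay, so swapping cyclohexylmethyl for 4-ethylphenyl gives no step that can be read. The series now gathers at one boundary: the limit of > 100000 nM in this assay, at which 3 of the 4 values shown sit.

The compounds shown leave open whether this swap changes cytotoxicity at all, since neither compound has an actual number.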